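This account rests on a few compounds, and the source may have more. Where it says the series, first, only, none or still open, it means among the compounds named here.

Compound 1 `O=C(CCCCC#Cc1cccnc1)c1ncc(-c2ccccn2)o1` is the weakest of the three measured compounds in an assay for inhibition of Fatty-acid amide hydrolase 1 (Rattus norvegicus) (a lower number here means a stronger inhibitor, a higher number a weaker inhibitor), where compound 1 gives 300 nM. Its two neighbours carry a carbocyclic ring in place of the pyridin-3-yl on the triple-bonded carbon: compound 2 `O=C(CCCCC#Cc1cccc(F)c1)c1ncc(-c2ccccn2)o1` gives 3.2 nM, and compound 3 `O=C(CCCCC#Cc1cccc([N+](=O)[O-])c1)c1ncc(-c2ccccn2)o1` gives 4.8 nM. The step from compound 1 is a 94-fold lower number from compound 1 to compound 2 (1.97 log units; beyond the scatter) and a 63-fold lower number from compound 1 to compound 3 (1.80 log units; beyond the scatter), while between the two carbocyclic analogues the change is only a 1.5-fold higher number from compound 2 to compound 3 (0.18 log units; within the scatter).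

Compound 4 `O=C(CCCCCSc1ccccc1)c1ncc(-c2ccccn2)o1` differs from compound 1 in one place: (phenylsulfanyl)methyl in place of 2-(pyridin-3-yl)ethynyl on a saturated chain carbon, four bonds along the chain from a carbonyl carbon. Among the compounds with values here, the change again removes the pyridin-3-yl from the chain end and brings in a six-membered aromatic ring of carbon only, which is the feature shared by the large steps to compound 2 and compound 3; the triple bond is also lost and a sulfur enters, a change for which no measured pair is available. Compound 4 is therefore expected to show a large drop in number, a 38-fold lower number from compound 1 to compound 4 (1.57 log units; beyond the scatter). In this assay compound 4 is estimated at 8 nM, within a range of 2 nM to 40 nM.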

Compound 4, inhibition constant: 3 nM
Compound 4: middle estimate off by 2.7-fold (0.43 log units), on the high side; the range from low to high includes it.
By their numbers in this assay, from the lowest: compounds 4, 2 and 3 (each within the scatter of the next); then compound 1.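

In this assay, the step from the pyridin-3-yl alkyne to the (phenylsulfanyl)methyl end is large (a 100-fold lower number from compound 1 to compound 4 (2.00 log units; beyond the scatter)), so a low number at this chain position does not depend on the triple bond. Nor does it depend on a fluoro or nitro group on the ring, since the phenyl of compound 4 is unsubstituted, and among these four compounds only compound 1, the one with a pyridine ring at the chain end, stands apart from the rest. Nothing given here bears on why the number falls.

The ring, the triple bond and the sulfur all change together in this step, so their shares cannot be separated. On these data alone, how a pyridin-3-yl on the sulfur, an oxygen in place of the sulfur, or a longer chain would read in this assay remains open.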